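Benzylamine series: hydrogen in place of methoxy

The source may hold more compounds than are shown below. What is called first, only, known or untested is meant among the compounds shown, and "the series" means these compounds.

Within the data shown here, compound 1 `COc1ccc(CNc2nc([SeH])nc3ccccc23)cc1` is the only measured member with a reported result. In a functional assay on HT-29 cells (Homo sapiens) for cytotoxicity, read by MTT assay, with a stated time of 72 h (a lower number here means a stronger inhibitor of growth, a higher number a weaker inhibitor of growth), compound 1 gives > 100000 nM, which is a limit of the assay and not a number. Compound 1 thus sits at the limit of > 100000 nM in this assay, at which 1 of the 2 values shown sits. Compound 2 `C[Se]c1nc([Se]C)c2cccnc2n1` has no result in this assay, recorded as "not determined" (no result reported), so nothing can be drawn from it. Compound 3 `[SeH]c1nc(NCc2ccccc2)c2ccccc2n1` is the unmeasured partner of compound 1: the two differ by hydrogen in place of methoxy on an aromatic carbon. Among the measured compounds shown here, no step between two measured compounds is available to gauge what such a change does in this assay, so the expected step that the limit leaves unreadable from compound 1 to compound 3 is none beyond the scatter, in no particular direction. Compound 3 is expected to give about 150000 nM in this assay, with a range from 50000 nM to 500000 nM, and the most likely outcome is again a limit rather than a number.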

Compound 3, concentration for total growth inhibition: > 100000 nM
Compound 3: a limit, no number; the forecaster's own chance of this, stated with the estimate: 85%; the middle value lies beyond the limit too.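

No step can be read between compound 1 and compound 3: both results in this assay are limits of the assay, not numbers. The compounds shown leave open whether hydrogen in place of methoxy on an aromatic carbon changes growth inhibition at all, and in which direction.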